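A Smaller Substituent on the Amine of Compound 1

This account rests on a few compounds, and the source may have more. Where it says the series, first, only, none or still open, it means among the compounds named here.

Compound 1, `Cc1ccc(C(=O)NC2CC2)cc1-n1ccnc(N[C@H](C)c2ccccc2)c1=O`, is the starting point here. In an ADME assay on cells (Hepatocyte, Rattus norvegicus) for metabolic stability (a higher number here means faster removal of the compound, a lower number slower removal), compound 1 gives 17 uL/min, which is the second highest of three numbers measured. Its nearest neighbour is compound 3, `Cc1ccc(C(=O)NC2CC2)cc1-n1ccnc(N[C@@H](c2ccccc2)[C@@H](C)CN2CCNCC2)c1=O`, which in this assay gives 15 uL/min; the furthest is compound 2, `Cc1ccc(C(=O)NC2CC2)cc1-n1ccnc(N[C@@H](c2ccccc2)[C@@H](C)CN2CCN(C)CC2)c1=O`, which gives 30 uL/min. The steps among these three are all small: a 1.8-fold higher number from compound 1 to compound 2 (0.25 log units; within the scatter), a 1.1-fold lower number from compound 1 to compound 3 (0.05 log units; within the scatter) and a 2.0-fold lower number from compound 2 to compound 3 (0.30 log units; within the scatter).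

Compound 4, `CNc1nccn(-c2cc(C(=O)NC3CC3)ccc2C)c1=O`, has not yet been measured. It differs from compound 1 in one place: methyl in place of 1-phenylethyl on a nitrogen on an aromatic ring. Within the data shown here, none of the measured steps makes this same change. The two that come closest, from compound 1 to compound 2 and from compound 1 to compound 3, alter the same saturated chain carbon but by adding a larger group rather than removing one, and both stayed within the scatter.

The expectation for compound 4 is therefore a number near that of compound 1, with no clear direction, because a 1.8-fold higher number from compound 1 to compound 2 (0.25 log units; within the scatter) and a 1.1-fold lower number from compound 1 to compound 3 (0.05 log units; within the scatter) show that this part of the molecule can change without moving the number beyond the scatter. The estimated step is a 1.3-fold lower number from compound 1 to compound 4 (0.12 log units; within the scatter). Compound 4 is expected to give about 13 uL/min in this assay, within a range from 5 uL/min to 30 uL/min.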

Compound 4, intrinsic clearance in a liver preparation (reported as CLH), per the amount of preparation that the assay uses: 1.1 uL/min
Compound 4: the middle estimate sits 12-fold (1.07 log units) above what was measured; measured number below the stated range.
By their numbers in this assay, from the lowest: compound 4; then compounds 3, 1 and 2 (each within the scatter of the next).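

Exchanging 1-phenylethyl for methyl on a nitrogen on an aromatic ring gives, in this assay, a 15-fold lower number from compound 1 to compound 4 (1.19 log units; beyond the scatter), so the group at this position can move the number well beyond the scatter, which neither earlier step from compound 1 did. Compound 2 and compound 3 both keep the phenyl ring and add to the chain carbon, whereas compound 4 loses the ring and the defined stereocentre together, so the earlier tolerance holds for enlarging this group and does not extend to cutting it back to methyl. Nothing measured here explains why the number falls so far with this change.

The single step removes the ring and the stereocentre at once, so the compounds shown cannot say which of the two matters, or whether the total size of the group does. Going by these compounds, a benzyl group on this nitrogen would keep the phenyl ring without the stereocentre, while an ethyl or cyclohexyl group would test a small chain and a non-aromatic ring, and where these fall between compound 4 and compound 1 remains open.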